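Swapping ethyl for 4-methoxybenzyl on the shared core

The source may hold more compounds than are shown below. What is called first, only, known or untested is meant among the compounds shown, and "the series" means these compounds.

Three measured compounds share one core and differ in a single region. In a functional assay on PC-3 cells (Homo sapiens) for antiproliferative activity, read by sulforhodamine B assay, with a stated time of 72 h (a higher number here means a weaker inhibitor, a lower number a stronger inhibitor), compound 1 (`COc1ncc(-c2ccc3ncc(NCc4ccc(C(F)(F)F)cc4)c(OC)c3c2)cc1NS(=O)(=O)c1ccc(F)cc1F`) gives 2880 nM, compound 2 (`COc1ncc(-c2ccc3ncc(NCc4ccccc4)c(OC)c3c2)cc1NS(=O)(=O)c1ccc(F)cc1F`) gives 4320 nM and compound 3 (`CCNc1cnc2ccc(-c3cnc(OC)c(NS(=O)(=O)c4ccc(F)cc4F)c3)cc2c1OC`) gives 4820 nM. Compound 3 therefore stands within the scatter of both others, as shown by a 1.1-fold higher number from compound 2 to compound 3 (0.05 log units; within the scatter) and by a 1.7-fold higher number from compound 1 to compound 3 (0.22 log units; within the scatter).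

Compound 4 (`COc1ccc(CNc2cnc3ccc(-c4cnc(OC)c(NS(=O)(=O)c5ccc(F)cc5F)c4)cc3c2OC)cc1`) has 4-methoxyphenyl in place of methyl on a saturated chain carbon bound to a nitrogen on an aromatic ring. The two steps above bear most directly on this change, since they link methyl with phenyl and with 4-(trifluoromethyl)phenyl at the same place. A further step, a 1.5-fold higher number from compound 1 to compound 2 (0.18 log units; within the scatter), concerns a substituent on that aromatic ring. None of the three exceeds the scatter, so no step beyond the scatter is expected in this assay. The expected change is a 1.3-fold lower number from compound 3 to compound 4 (0.13 log units; within the scatter). Compound 4 is estimated at 3600 nM, with an expected range of 1900 nM to 6800 nM.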

Compound 4, half-maximal inhibitory concentration: 4520 nM
Compound 4: middle estimate off by 1.3-fold (0.10 log units), on the low side; measured number inside the range.
By their numbers in this assay, from the lowest: compounds 1, 2, 4 and 3 (each within the scatter of the next).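

In this assay, 4-methoxyphenyl in place of methyl on the saturated chain carbon adds 8 heavy atoms in all, an aromatic ring and a hydrogen-bond acceptor, yet the step stays within the scatter (a 1.1-fold lower number from compound 3 to compound 4 (0.03 log units; within the scatter)). Until now, that aromatic carbon had carried only hydrogen or trifluoromethyl; methoxy now gives steps within the scatter from both, in place of hydrogen (a 1.0-fold higher number from compound 2 to compound 4 (0.02 log units; within the scatter)) and in place of trifluoromethyl (a 1.6-fold higher number from compound 1 to compound 4 (0.20 log units; within the scatter)). No evidence at hand explains this flat set of results.

Going by these compounds, whether an amine or a carboxylic acid on that aromatic carbon, or a longer chain in place of ethyl, would give a step beyond the scatter remains open. So does whether these changes would still leave the number within the scatter on an altered core.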